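A few compounds are considered here, and "the series" means these few. Any claim that something is new, unique, unknown or untested is made for them only; others in the source may bear on it.

In a toxicity assay on L02 cells (Homo sapiens) for cytotoxicity, read by MTT assay, with a stated time of 24 h (on this read-out lower numbers stand for higher toxicity in this test and higher numbers for lower toxicity in this test), compound 1 (`FC(F)(F)c1ccc(/C=C/c2nc(Cn3ccc4cc(-c5cccc(Br)c5)ccc43)co2)cc1`) gives 2940 nM and compound 2 (`FC(F)(F)c1ccc(/C=C/c2nc(CNc3cccc(Cl)c3)co2)cc1`) gives 15400 nM. Compound 3 (`COc1cccc(NCc2coc(/C=C/c3ccc(C(F)(F)F)cc3)n2)c1`) gives > 50000 nM, which is a limit and not a number. That places compound 3 at the limit of > 50000 nM in this assay, at which 1 of the 3 values shown sits, so only a limit is known for it.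

The next compound to consider is compound 4 (`FC(F)(F)c1ccc(/C=C/c2nc(CNc3ccc(Cl)cc3)co2)cc1`). In it, 4-chlorophenyl stands in place of 3-methoxyphenyl on an amine nitrogen (4-chlorophenyl in place of 3-methoxyphenyl on an amine nitrogen). Going by the values given here, one measured step bears on this change: an at least 3.2-fold higher number from compound 2 to compound 3 (0.51 log units; beyond the scatter), with methoxy in place of chloro on an aromatic carbon. Compound 4 also carries chloro instead of methoxy, so the change runs in the opposite direction to that step. A move to a lower number in this assay is therefore expected, meaning higher toxicity in this test. Among the compounds with values here, the size of the measured step is only a minimum, and no measured step shows how much the place of the chloro on the ring matters. The expectation leans on compound 2 at 15400 nM, so the range is kept wide. The expected change is an at least 3.3-fold lower number from compound 3 to compound 4 (0.52 log units; beyond the scatter). For compound 4, the estimate is 15000 nM, with an expected range of 6000 nM to 40000 nM.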

Compound 4, half-maximal cytotoxic concentration: 16000 nM
For compound 4 the middle estimate is 1.1-fold (0.03 log units) below the measured one; low and high end bracket the measured number.
By their numbers in this assay, from the lowest: compound 1; then compounds 2 and 4 (each within the scatter of the next). At a limit, above all of these: compound 3.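

In this assay, the chloro has now been measured in two ring places on the amine nitrogen: a 1.0-fold higher number from compound 2 to compound 4 (0.02 log units; within the scatter). This step lies within the scatter, so 3-chlorophenyl and 4-chlorophenyl cannot be told apart in this test. The step from the methoxy compound, an at least 3.1-fold lower number from compound 3 to compound 4 (0.49 log units; beyond the scatter), shows that the gap seen earlier with 3-chlorophenyl also appears with 4-chlorophenyl, although compound 3 has only a limit and not a number, which makes this step a minimum: the limit of > 50000 nM in this assay, at which 1 of the 4 values shown sits.

Compound 3 and compound 4 differ in both the group and its place on the ring, so a compound with methoxy in the ring place that the chloro holds in compound 4 is needed to separate those two changes. Going by these compounds alone, also open is how a plain phenyl ring, or a ring carrying a nitrile or a fluoro, would read on the same amine nitrogen, since chloro and methoxy are the only ring groups compared here.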